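The source may hold more compounds than are shown below. What is called first, only, known or untested is meant among the compounds shown, and "the series" means these compounds.

Working notes on the series. Compound 1 `O=C(O)c1ccc(/C=C2\SC(=S)N(c3ccccc3)C2=O)cc1`, compound 2 `O=C(O)c1ccc(COc2ccc(/C=C3\SC(=S)N(c4ccc([N+](=O)[O-])cc4)C3=O)cc2)cc1` and compound 3 `O=C(COc1ccc(/C=C2\SC(=S)N(c3ccc([N+](=O)[O-])cc3)C2=O)cc1)Nc1ccc(C(=O)O)cc1` share one core. In an assay on isolated protein for inhibition of Apoptosis regulator Bcl-2 (Homo sapiens), read by fluorescence polarization (a lower number here means a stronger inhibitor, a higher number a weaker inhibitor), compound 1 returns only a limit, > 10000 nM. Compound 2 also returns a limit in this assay, > 10000 nM. Compound 3 likewise gives a limit, > 10000 nM. Where the values sit is summed up by the limit of > 10000 nM in this assay, at which 3 of the 3 values shown sit. Among the compounds with values here, the one measured step, a step that the two limits leave unreadable from compound 2 to compound 3, cannot be read in size or direction. Compound 2 thus stands at the limit of this assay, with no number of its own, and the two further values shown stand at the same limit.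

Compound 4 `O=C(O)c1ccc(COc2ccc(/C=C3\SC(=S)N(c4ccc(I)cc4)C3=O)cc2)cc1` differs from compound 2 by iodo in place of nitro on an aromatic carbon. Within the data shown here, no measured step touches this change, and the only measured step gives no readable size. No shift beyond the scatter is therefore expected; the expected step is a step that the limit leaves unreadable from compound 2 to compound 4. Compound 4 is estimated at 12000 nM in this assay, with a range from 3000 nM to 50000 nM, and most likely it too will return only a limit.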

Compound 4, inhibition constant: 4300 nM
Estimate against measurement, compound 4: 2.8-fold (0.45 log units) above; low and high end bracket the measured number.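

In this assay, iodo in place of nitro on an aromatic carbon para to a large group gives an at least 2.3-fold lower number from compound 2 to compound 4 (0.36 log units; beyond the scatter). The printed size is a minimum, and the change replaces three heavy atoms and two hydrogen-bond acceptors with a single iodine, so the data cannot say which of these differences matters. Compound 4, at 4300 nM, is the one compound shown with a number of its own. This position is the only place so far where a change moves the read-out off the limit: the limit of > 10000 nM in this assay, at which 3 of the 4 values shown sit.

As far as these compounds go, it remains open whether bromo, chloro or an amine at this position would stay at the limit or give a number. From the compounds shown here alone, it is also open whether iodo would give a number on the chain of compound 3, with its (4-carboxyphenyl)carbamoyl group.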